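Fluorosulfonyl placement on the amide nitrogen: two linker series

This account rests on a few compounds, and the source may have more. Where it says the series, first, only, none or still open, it means among the compounds named here.

Measured so far in an assay on isolated protein for inhibition of Dihydrofolate reductase (Mus musculus); a lower number here means a less potent compound, a higher number a more potent compound, by a factor of ten per unit of this negative logarithm:
compound 1 `CC1(C)N=C(N)N=C(N)N1c1ccc(OCCCNC(=O)Nc2ccc(S(=O)(=O)F)cc2)c(Cl)c1` — 7.68
compound 2 `CC1(C)N=C(N)N=C(N)N1c1ccc(OCCCNC(=O)Nc2cccc(S(=O)(=O)F)c2)c(Cl)c1` — 7.28
compound 3 `CC1(C)N=C(N)N=C(N)N1c1ccc(OCc2cccc(C(=O)Nc3cccc(S(=O)(=O)F)c3)c2)c(Cl)c1` — 7.24

Compound 1 and compound 2 share one core and differ in a single place: 4-(fluorosulfonyl)phenyl in place of 3-(fluorosulfonyl)phenyl on an amide-type nitrogen. In this assay this change made a number 0.40 log units higher from compound 2 to compound 1 (beyond the scatter), a modest gain but beyond the scatter of the measurement.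

Compound 3 carries a different core; the difference between the core of compound 3 and the core of compound 2 is not broken down here. Compound 3 has the lowest number of the three in this assay. Its gap to compound 2 is within the scatter, so no order between those two can be read; its gap to compound 1 is beyond the scatter.

Compound 4 `CC1(C)N=C(N)N=C(N)N1c1ccc(OCc2cccc(C(=O)Nc3ccc(S(=O)(=O)F)cc3)c2)c(Cl)c1` has not yet been measured. It differs from compound 3 as 4-(fluorosulfonyl)phenyl in place of 3-(fluorosulfonyl)phenyl on an amide-type nitrogen. The place of the change reads word for word as it does between compound 2 and compound 1, so this is the same change made on the other core. It has been seen once only, and on a different core, so a single precedent is all that supports a forecast. The step from compound 3 to compound 4 in this assay is expected to be about a number 0.40 log units higher from compound 3 to compound 4 (beyond the scatter), because the same change gave a number 0.40 log units higher from compound 2 to compound 1 (beyond the scatter). The range is set wide to allow for the core differing. Compound 4 is therefore estimated at 7.64 in this assay, with the range 7.15 to 8.1.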

Compound 4, logarithm of the reciprocal of the active concentration, log(1/C): 6.92
For compound 4 the middle estimate is 0.72 log units above the measured one; the measured number lies below the stated range.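

In this assay, 4-(fluorosulfonyl)phenyl in place of 3-(fluorosulfonyl)phenyl on an amide-type nitrogen gave a number 0.32 log units lower from compound 3 to compound 4 (beyond the scatter) on the core of compound 3, so the step taken from the core of compound 1 did not hold in direction, and a preference for either placement cannot be stated for the series as a whole. Set side by side, the two steps point opposite ways and differ by more than measurement scatter would explain: the same change on two cores in this assay, a number 0.40 log units higher (beyond the scatter) from compound 2 to compound 1 and a number 0.32 log units lower (beyond the scatter) from compound 3 to compound 4, 0.72 log units apart, beyond the scatter of two such steps. This shows that, across these two cores, the effect of the change cannot be carried from one to the other, but with one pair per core it does not show which part of the cores sets the direction, nor how the change would run on any third core.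

The two cores differ in more than one place, so the compounds shown leave open which of those differences goes with the reversal, and whether a longer chain on either core would keep or change the direction of the step. Also open, as far as these compounds go, is whether a carboxylic acid in place of the fluorosulfonyl group would give the same order between the two placements on each core.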